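The compounds below may be only part of what the source reports. "The series", "measured", "known", "first", "only" and "open" are said of these compounds alone.

In a functional assay on the whole organism (strain Sprague-Dawley) for inhibition, with Rattus norvegicus as the target, with a stated time of 10 min (on this read-out higher numbers stand for an effect only at larger amounts of compound and lower numbers for an effect already at smaller amounts), compound 1 `CCC(C)Oc1ccccc1-c1ncc(C(=O)O)c(=O)[nH]1` gives 0.5 mg/kg, compound 2 `CCOc1ccc(Cl)cc1-c1ncc(C(=O)O)c(=O)[nH]1` gives 0.5 mg/kg and compound 3 `CCOC(=O)c1cnc(-c2cc(Cl)ccc2OCC)[nH]c1=O` gives 0.5 mg/kg, so compound 3 stands level with both. Compound 4 `CCOC(=O)c1cnc(-c2cc(S(N)(=O)=O)ccc2OCC)[nH]c1=O` carries sulfamoyl in place of chloro on an aromatic carbon, para to an ethoxy group: sulfamoyl in place of chloro on an aromatic carbon. Among the measured compounds shown here, the only measured single-place step shows no change at the digits printed from compound 2 to compound 3 (within the scatter). That step lies at another place and keeps the chloro, so no measurement tests this exchange or gives it a direction. In this assay the expected outcome is therefore no step beyond the scatter, with wide uncertainty: no change at the digits printed from compound 3 to compound 4 (within the scatter). Compound 4 is estimated at 0.5 mg/kg, with an expected range of 0.12 mg/kg to 2 mg/kg.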

Compound 4, dose for 50% inhibition: 50 mg/kg
Beside the measured number, compound 4's estimate is 100-fold (2.00 log units) below it; the measured number lies above the stated range.
By their numbers in this assay, from the lowest: compounds 1, 2 and 3 (each within the scatter of the next); then compound 4.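

In this assay, among the compounds shown here, the aromatic carbon para to an ethoxy group proves sensitive: sulfamoyl in place of chloro gives a 100-fold higher number from compound 3 to compound 4 (2.00 log units; beyond the scatter), whereas the only earlier single-place step, at another place, gave no change at the digits printed from compound 2 to compound 3 (within the scatter). For the compounds shown here, this is the first change to move the read-out beyond the scatter, and it places that change on the aromatic carbon that carried chloro. No available evidence explains the step.

As far as these compounds go, it remains open whether fluoro, methyl or an amine at this carbon would keep the level of compound 3. From the compounds shown here alone, whether sulfamoyl has the same effect alongside the free carboxylic acid of compound 2 also remains open.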